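The compounds below may be only part of what the source reports. "The series", "measured", "known", "first", "only" and "open" are said of these compounds alone.

Compound 1 `COc1cc(C(=O)c2sc3ccccc3c2-c2ccccc2)cc(OC)c1OC` gives 1900 nM
Compound 2 `COc1ccc(-c2c(C(=O)c3cc(OC)c(OC)c(OC)c3)sc3ccccc23)cc1` gives 4200 nM
Compound 3 `COc1ccccc1-c1c(C(=O)c2cc(OC)c(OC)c(OC)c2)sc2ccccc12` gives 5000 nM

All three values come from a functional assay on HeLa cells (Homo sapiens) for antiproliferative activity, read by MTT assay, with a stated time of 72 h (a lower number here means a stronger inhibitor, a higher number a weaker inhibitor), and the compounds differ only in the methoxy substitution of one phenyl ring. Compound 2 stands with compound 3 at the high end of these numbers, and the two cannot be told apart (a 1.2-fold higher number from compound 2 to compound 3 (0.08 log units; within the scatter)). Compound 1 lies lower (a 2.2-fold higher number from compound 1 to compound 2 (0.34 log units; beyond the scatter)).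

Compound 4 `COc1ccc(OC)c(-c2c(C(=O)c3cc(OC)c(OC)c(OC)c3)sc3ccccc23)c1` carries 2,5-dimethoxyphenyl in place of 4-methoxyphenyl on an aromatic carbon. The closest evidence is methoxy in place of hydrogen, which gave a modest step each time it was measured (a 2.2-fold higher number from compound 1 to compound 2 (0.34 log units; beyond the scatter) and a 2.6-fold higher number from compound 1 to compound 3 (0.42 log units; beyond the scatter)). For the measured compounds named here, no measured compound has two methoxy groups on this ring, so whether such steps add up is untested. A further small move towards a higher number is therefore expected, possibly none beyond the scatter. The estimated move is modest at most (a 1.4-fold higher number from compound 2 to compound 4 (0.15 log units; within the scatter)). The expected value for compound 4 is 6000 nM (estimated range 2500 nM to 15000 nM).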

Compound 4, half-maximal inhibitory concentration: 10000 nM
Beside the measured number, compound 4's estimate is 1.7-fold (0.22 log units) below it, within the range that was stated.
By their numbers in this assay, from the lowest: compound 1; then compounds 2, 3 and 4 (each within the scatter of the next, the first and the last beyond it).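

For the compounds shown here, compound 4 is the only compound here with two methoxy groups on this ring, and in this assay the 2,5-dimethoxyphenyl group gives a 2.4-fold higher number from compound 2 to compound 4 (0.38 log units; beyond the scatter). Measured against the unsubstituted phenyl group, the full change gives a 5.3-fold higher number from compound 1 to compound 4 (0.72 log units; beyond the scatter), while the second methoxy group taken alone gives a 2.0-fold higher number from compound 3 to compound 4 (0.30 log units; within the scatter), which cannot separate compound 3 from compound 4. The earlier compounds could not test whether methoxy steps add up, and the two steps now available agree in size: the same change on two cores in this assay, a 2.2-fold higher number (0.34 log units; beyond the scatter) from compound 1 to compound 2 and a 2.0-fold higher number (0.30 log units; within the scatter) from compound 3 to compound 4, 1.1-fold (0.04 log units) apart, within the scatter of two such steps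

As far as these compounds go, the ring carries only hydrogen and methoxy in these compounds, so it stays open whether the higher numbers follow methoxy in particular or any group placed on this ring. A hydroxyl group, a chlorine or an amine on this ring would address that question.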